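The source may hold more compounds than are shown below. What is called first, only, known or untested is meant among the compounds shown, and "the series" means these compounds.

Working notes on the series. Of the compounds shown here, three share one core and have been measured in an assay on CHO cells for displacement of a labelled ligand from adenosine receptor A3 (Homo sapiens), read by scintillation counting, with a stated time of 120 min, tested at 10 uM; on this read-out lower numbers stand for less inhibition and higher numbers for more inhibition at the one concentration tested (going by the name of the read-out). Compound 1 `Nc1scc(CN2CCN(c3ccc(F)cc3Cl)CC2)c1C(=O)c1ccc(Cl)cc1` gives 0%, compound 2 `Nc1scc(CN2CCN(c3cccnc3)CC2)c1C(=O)c1ccc(Cl)cc1` gives 0%, and compound 3 `Nc1scc(CN2CCN(c3ccncc3)CC2)c1C(=O)c1ccc(Cl)cc1` gives 2%. Compound 3 carries the nominally highest of the three numbers, but the steps of a number 2 percentage points higher from compound 1 to compound 3 (within the scatter) and a number 2 percentage points higher from compound 2 to compound 3 (within the scatter) both fall within the scatter, so the three sit together. Compound 4 `Nc1scc(CN2CCN(C3CCCCCC3)CC2)c1C(=O)c1ccc(Cl)cc1` differs from compound 3 by cycloheptyl in place of pyridin-4-yl on an amine nitrogen in a ring. Within the data shown here, the steps that bear on this exchange the group on the ring nitrogen, namely no change at the digits printed from compound 1 to compound 2 (within the scatter) and the two just named, and none moves the number beyond the scatter, though none introduces a non-aromatic ring. The expected step of a number 1 percentage points higher from compound 3 to compound 4 (within the scatter) is therefore none beyond the scatter. Compound 4 is estimated at 3%, within -5% to 15%.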

Compound 4, a percentage reported as inhibition, at one concentration (the size of the read-out at that concentration, not a potency): 0%
The estimate for compound 4 lay 3 percentage points above the measured number, and the stated range covers the measured number.
By their numbers in this assay, from the lowest: compounds 1, 2, 4 and 3 (each within the scatter of the next).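

Cycloheptyl brings the first non-aromatic ring of carbon only to the amine nitrogen, and this assay shows a number 2 percentage points lower from compound 3 to compound 4 (within the scatter) and no change at the digits printed from compound 2 to compound 4 (within the scatter) and no change at the digits printed from compound 1 to compound 4 (within the scatter) as well. An aromatic ring on this nitrogen is therefore not required for the number to stay within the scatter of the other three compounds. Nothing available explains this result. As far as these compounds go, what a longer chain, or a ring carrying a carboxylic acid or an amine, would give at this nitrogen stays open. Also open, from the compounds shown here alone, is whether any change here moves the shared core beyond the scatter.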